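Hydroxy analogue of the diaryl urea series on ovarian cells

The source may hold more compounds than are shown below. What is called first, only, known or untested is meant among the compounds shown, and "the series" means these compounds.

compound 1 `O=C(Nc1cccc(-n2cc(-c3ccncc3)c(-c3ccc(Cl)c(O)c3)n2)c1)Nc1ccc(Cl)c(Cl)c1`: > 32500 nM
compound 2 `COc1cc(-c2nn(-c3cccc(NC(=O)Nc4ccc(Cl)c(C(F)(F)F)c4)c3)cc2-c2ccncc2)ccc1Cl`: > 32500 nM

In a functional assay on SK-OV-3 cells (Homo sapiens) for inhibition, read by sulforhodamine B assay, with a stated time of 48 h (a higher number here means that more compound is tolerated, a lower number that less compound is tolerated), compound 2 gives only a limit, > 32500 nM. Compound 1 also stops at a limit in this assay, > 32500 nM. Both values sit on (the limit of > 32500 nM in this assay, at which 2 of the 2 values shown sit), so no ordering of the two is possible. Compound 3 `O=C(Nc1cccc(-n2cc(-c3ccncc3)c(-c3ccc(Cl)c(O)c3)n2)c1)Nc1ccc(Cl)c(C(F)(F)F)c1` differs from compound 2 by hydrogen in place of methyl on an oxygen on an aromatic ring, methoxy to hydroxy. Compound 1 already carries that hydroxy group and stays at the limit, so no step beyond the scatter is expected. The step from compound 2 to compound 3 is expected to be a step that the limit leaves unreadable from compound 2 to compound 3. Compound 3 is expected at 40000 nM, within 20000 nM to 100000 nM.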

Compound 3, concentration lethal to 50% of the cells: > 32500 nM
Compound 3 gave a limit, no number (the forecaster's own chance of this, stated with the estimate: 80%); the middle value is on the limit's open side.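

No step can be read among compound 1, compound 2 and compound 3 in this assay, as all three values are limits: the limit of > 32500 nM in this assay, at which 3 of the 3 values shown sit. From the compounds shown here alone, whether methoxy to hydroxy, or trifluoromethyl in place of chloro, changes this read-out at all remains open.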